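This account rests on a few compounds, and the source may have more. Where it says the series, first, only, none or still open, it means among the compounds named here.

Measured in an assay on isolated protein for inhibition of malate dehydrogenase, mitochondrial (Sus scrofa), with stated times of 45 min and 30 min (a higher number here means a weaker inhibitor, a lower number a stronger inhibitor), each value being a limit of the assay rather than a number:

compound 1, `Cc1ccc(S(=O)(=O)Nc2ccc3oc(-c4ccccc4)nc3c2)cc1`: > 63000 nM
compound 2, `COc1cccc(S(=O)(=O)Nc2ccc3oc(-c4ccccc4)nc3c2)c1`: > 63000 nM
compound 3, `O=S(=O)(Nc1ccc2oc(-c3ccccc3)nc2c1)c1ccccc1F`: > 63000 nM

Compound 3 stands at the limit of this assay, and it is a limit only; the same holds for the two other values, so all three sit where the limit of > 63000 nM in this assay, at which 3 of the 3 values shown sit, describes. The steps among them, a step that the two limits leave unreadable from compound 1 to compound 2, a step that the two limits leave unreadable from compound 1 to compound 3 and a step that the two limits leave unreadable from compound 2 to compound 3, are unreadable: two limits give no size and no direction.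

Compound 4, `O=S(=O)(Nc1ccc2oc(-c3ccccc3)nc2c1)c1ccc(Cl)cc1`, is not yet measured. Its change from compound 3 is 4-chlorophenyl in place of 2-fluorophenyl on a sulfonyl sulfur. The measured steps that bear on it are the three exchanges of the aryl group on the sulfonyl sulfur, and none of them yields a readable size, so no direction can be drawn for this assay from them.

The expectation for compound 4 therefore rests on the shared position of compounds 1, 2 and 3 at the limit: compound 4 is expected to remain there as well, giving 100000 nM within 30000 nM to 400000 nM, most likely again as a limit. The step this estimate implies, a step that the limit leaves unreadable from compound 3 to compound 4, is itself expected to be unreadable.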

Compound 4, half-maximal inhibitory concentration: > 63000 nM
Compound 4 was reported as a limit; the forecaster's own chance of this, stated with the estimate: 85%; the middle value lies beyond the limit too.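

In this assay compound 4 gives > 63000 nM, which is a limit of the assay. No step from compound 1, compound 2 or compound 3 to compound 4 can be read, and all four stand together: the limit of > 63000 nM in this assay, at which 4 of the 4 values shown sit.

The compounds shown leave open whether any aryl group on the sulfonyl sulfur of the shared core gives a readable value in this assay.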